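Carboxylic acid to methyl amide on a tricyclic lactone core

The compounds below may be only part of what the source reports. "The series", "measured", "known", "first", "only" and "open" are said of these compounds alone.

Measured so far:
compound 1 `CC(C)[C@H]1CC[C@@]2(CO2)[C@H]2C(=O)OCC(C(=O)OCc3ccc(-c4ccc([N+](=O)[O-])cc4)o3)=C[C@H]12` — 1640 nM
compound 2 `CC(C)[C@H]1CC[C@@]2(CO2)[C@H]2C(=O)OCC(C(=O)O)=C[C@H]12` — 1340 nM

Of the compounds shown here, two have been tested in a functional assay on A-375 cells (Homo sapiens) for inhibition, with a stated time of 72 h; a higher number here means a weaker inhibitor, a lower number a stronger inhibitor. Compound 1 carries a nitrophenylfuranylmethyl ester and in this assay compound 1 gives 1640 nM. Compound 2 carries the free carboxy group on the shared core and in this assay compound 2 gives 1340 nM. For the measured compounds named here, the two numbers lie within the usual scatter of each other, so neither compound can be set apart from the other on these data, and there is no step between measured compounds from which a trend could be read.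

Compound 3 `CNC(=O)C1=C[C@@H]2[C@@H](C(C)C)CC[C@@]3(CO3)[C@H]2C(=O)OC1` remains to be measured in this assay. It differs from compound 2 as follows: methylamino in place of hydroxy on a carbonyl carbon. Because compound 1 gives 1640 nM and compound 2 gives 1340 nM, numbers within the scatter of each other, the carbonyl substituent appears to matter little here, and compound 3 is expected to sit near compound 2, with a step of a 1.1-fold higher number from compound 2 to compound 3 (0.05 log units; within the scatter) not beyond the scatter. The estimate for compound 3 in this assay is 1500 nM, with a range from 600 nM to 4000 nM.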

Compound 3, half-maximal inhibitory concentration: 4150 nM
Compound 3: the middle estimate sits 2.8-fold (0.44 log units) below what was measured; the whole stated range lies below it.
By their numbers in this assay, from the lowest: compounds 2 and 1 (each within the scatter of the next); then compound 3.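

In this assay, for the compounds shown here, methylamino in place of hydroxy on a carbonyl carbon gives the first step beyond the scatter, a 3.1-fold higher number from compound 2 to compound 3 (0.49 log units; beyond the scatter). The change from carboxy to methylcarbamoyl therefore shows that the substituent on this carbonyl can shift the number, and in this case towards weaker inhibition, which compound 1 and compound 2 could not show with values within the scatter of each other. The step is modest, and no measurement in hand accounts for it.

Still open, going by these compounds, is whether the step follows from the amide nitrogen or from its methyl group, a question that the unsubstituted carboxamide, the dimethylamide and the simple methyl ester on the shared core would separate. Also open, on these data alone, is whether a longer chain on the amide nitrogen, such as ethyl or butyl, or a cyclic amine such as morpholine or piperidine joined through the same carbonyl, would move the number further from that of compound 2 or bring it back.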